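From pyrrolidin-1-yl to octylsulfanyl on a shared core

The compounds below may be only part of what the source reports. "The series", "measured", "known", "first", "only" and "open" are said of these compounds alone.

Compound 3 `Nc1nc(N2CCCC2)c2ncn(/C=C3/CC3(CO)CO)c2n1` reaches only a limit in an ADME assay on Akata cells (Homo sapiens) for cytotoxicity, with a stated time of 7 days (a lower number here means that less compound is tolerated, a higher number that more compound is tolerated), and that limit is > 24000 nM. Compound 2 `CN(C)c1nc(N)nc2c1ncn2/C=C1/CC1(CO)CO` also gives only a limit, > 24000 nM. Compound 1 `CCOc1nc(N)nc2c1ncn2/C=C1/CC1(CO)CO` likewise gives only a limit, > 20000 nM. So no exact concentration is available for any of the three.

Compound 4 `CCCCCCCCSc1nc(N)nc2c1ncn2/C=C1/CC1(CO)CO` carries octylsulfanyl in place of pyrrolidin-1-yl on an aromatic carbon. The measured steps at this carbon are the closest guide: a step that the two limits leave unreadable from compound 1 to compound 2, a step that the two limits leave unreadable from compound 1 to compound 3 and a step that the two limits leave unreadable from compound 2 to compound 3. None of them offers a size to carry forward. Going by the values given here, the long octylsulfanyl chain also has no counterpart among the measured groups, so any forecast must stay loose.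

A cautious expectation in this assay is an at least 1.6-fold lower number from compound 3 to compound 4 (0.20 log units; that floor lies within the scatter), leaning towards less compound being tolerated, though the result may again be only a limit. Compound 4 is estimated at 15000 nM, with an expected range of 4000 nM to 40000 nM.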

Compound 4, half-maximal cytotoxic concentration: > 20000 nM
Compound 4: only a limit was reported (the forecaster's own chance of this, stated with the estimate: 55%); middle value at least 1.3-fold (0.12 log units) away from the limit.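

Compound 4 gives only a limit, > 20000 nM, in this assay. Going by these compounds alone, compound 1, compound 2 and compound 3 also stand at limits, so no step to compound 4 can be read. Going by these compounds, the exact concentrations of all four compounds stay open, as does whether changing the group on this aromatic carbon shifts them at all.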